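Lengthening the chain of compound 1: working notes

The source may report more compounds than this note shows. Statements on the series, on what has been measured and on what is new or still open speak of the compounds shown alone.

Compound 1 `COc1ccc(N(C)c2nc(C)nc3ccccc23)cc1C(=O)OCC[Se]C#N` gives 1480 nM
Compound 2 `COc1ccc(N(C)c2nc(C)nc3ccccc23)cc1OCC[Se]C#N` gives 13 nM

Going by the values given here, in a functional assay on MDA-MB-231 cells (Homo sapiens) for inhibition, read by MTT assay, with a stated time of 48 h (a higher number here means a weaker inhibitor, a lower number a stronger inhibitor), compound 1 stands at 1480 nM, the higher of the two numbers so far. Among the compounds with values here, the only measured step is a 110-fold lower number from compound 1 to compound 2 (2.06 log units; beyond the scatter). Compound 3 `COc1ccc(N(C)c2nc(C)nc3ccccc23)cc1C(=O)OCCCCC[Se]C#N` is the next case to read. It keeps the shared core and the carbonyl of compound 1 and differs only at the chain: a group of 6 heavy atoms (4 carbon, 1 nitrogen, 1 selenium; no ring) in place of a group of 3 heavy atoms (1 carbon, 1 nitrogen, 1 selenium; no ring), on a saturated chain carbon, two bonds along the chain from an oxygen next to a carbonyl group.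

The measured step is large, but it falls on an aromatic carbon, whereas this change falls on a saturated chain carbon. It therefore gives no direct measure here. Within the data shown here, no measured pair varies the chain alone, so the data set no direction for this change, and a wide range is needed. In this assay no shift beyond the scatter is expected, and compound 1 remains the reference point.

The estimate amounts to an expected 1.2-fold lower number from compound 1 to compound 3 (0.09 log units; within the scatter). For compound 3 the expected value is 1200 nM, with an estimated range of 300 nM to 5000 nM.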

Compound 3, half-maximal inhibitory concentration: 851 nM
Beside the measured number, compound 3's estimate is 1.4-fold (0.15 log units) above it; the measured number falls inside the stated range.
By their numbers in this assay, from the lowest: compound 2; then compounds 3 and 1 (each within the scatter of the next).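

In this assay, the step at this saturated chain carbon is a 1.7-fold lower number from compound 1 to compound 3 (0.24 log units; within the scatter): with the carbonyl kept, the group of 6 heavy atoms in place of the group of 3 heavy atoms leaves compound 1 and compound 3 within the scatter of each other. Going by these compounds alone, this is the first reading of the chain alone, and for this pair the added length gives no separation in this read-out, so the single pair offers no direction for chain length. The step of a 110-fold lower number from compound 1 to compound 2 (2.06 log units; beyond the scatter) therefore remains the only one beyond the scatter in the series, and it falls on an aromatic carbon rather than on this chain, while no available evidence bears on why compound 1 and compound 3 read so closely.

The compounds shown leave open whether a longer chain on the carbonyl would stay within the scatter of compound 1, and whether the same lengthening on the chain of compound 2 would behave as it does here. They also leave open how this place would respond to a group of a different kind, such as an amine or a carboxylic acid at the end of the chain.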